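Methyl to chloro on the one-carbon thioether arm

A few compounds are considered here, and "the series" means these few. Any claim that something is new, unique, unknown or untested is made for them only; others in the source may bear on it.

Compound 1 `C#CCNC1CCc2c(SCCc3cccc(C)c3)cccc21` is the anchor: in an assay on isolated protein for inhibition of Amine oxidase [flavin-containing] B (Homo sapiens) (a higher number here means a weaker inhibitor, a lower number a stronger inhibitor), compound 1 gives 0.35 nM. Compound 3 `C#CCNC1CCc2c(SCCc3ccc(C)cc3)cccc21` gives 25800 nM, and the step of a 74000-fold higher number from compound 1 to compound 3 (4.87 log units; beyond the scatter) shows how sharply the methyl position matters. Compound 2 `C#CCNC1CCc2c(SCc3cccc(C)c3)cccc21` stands apart. In this assay compound 2 reaches only the limit > 100000 nM, a boundary of the measurement rather than a number (the limit of > 100000 nM in this assay, at which 1 of the 3 values shown sits). Compound 4 `C#CCNC1CCc2c(SCc3cccc(Cl)c3)cccc21` differs from compound 2 by chloro in place of methyl on an aromatic carbon. Among the measured compounds shown here, no measured step covers this exchange, and the one measured step, from a methyl shift, bears on it only loosely. Compound 4 is therefore expected to stay near the limit, with the step of a number no higher from compound 2 to compound 4 (the limit leaves the size open) meaning little change. Compound 4 is estimated at 100000 nM, within 20000 nM to 500000 nM.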

Compound 4, half-maximal inhibitory concentration: 23300 nM
The estimate for compound 4 lay 4.3-fold (0.63 log units) above the measured number; the range from low to high includes it.
By their numbers in this assay, from the lowest: compound 1; then compounds 4 and 3 (each within the scatter of the next). At a limit, above all of these: compound 2.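

On the one-carbon thioether arm, 3-chlorophenyl in place of 3-methylphenyl gives an at least 4.2-fold lower number from compound 2 to compound 4 (0.63 log units; beyond the scatter), so this exchange brings the series off the assay limit and to a readable value. Among the compounds shown here, it is the first sign that the group at this aromatic carbon can shift the result on this arm, not only on the longer arm of compound 1. The true size of the step stays open, as the entry for compound 2 is a limit and not a number: the limit of > 100000 nM in this assay, at which 1 of the 4 values shown sits.

Open, on these data alone, is whether a fluoro or a methoxy at this place would go further than chloro. Also open, as far as these compounds go, is whether chloro in place of methyl would act alike on the longer thioether arm of compound 1.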